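The source may report more compounds than this note shows. Statements on the series, on what has been measured and on what is new or still open speak of the compounds shown alone.

Compound 1 `N#Cc1cc(=O)[nH]c(=O)n1[C@@H]1O[C@H](CO)[C@@H](O)[C@H]1O`: > 50000 nM
Compound 2 `O=c1cc(I)n([C@@H]2O[C@H](CO)[C@@H](O)[C@H]2O)c(=O)[nH]1`: > 50000 nM

Both entries come from a functional assay on MCF7 cells (Homo sapiens) for antiproliferative activity, read by WST assay, with a stated time of 3 days (a higher number here means a weaker inhibitor, a lower number a stronger inhibitor), and both are limits of the assay rather than numbers. Compound 2 therefore has no exact position on the scale. Among the compounds with values here, its only reading is the limit > 50000 nM. Within the data shown here, the same picture holds across the series so far: the limit of > 50000 nM in this assay, at which 2 of the 2 values shown sit.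

The next change replaces the iodo group of compound 2 with dimethylamino, on an aromatic carbon next to the ring nitrogen, and gives compound 3 `CN(C)c1cc(=O)[nH]c(=O)n1[C@@H]1O[C@H](CO)[C@@H](O)[C@H]1O`. The counted difference is dimethylamino in place of iodo on an aromatic carbon.

Among the measured compounds shown here, only one measured step bears on this exchange: a step that the two limits leave unreadable from compound 1 to compound 2. It also swaps one group for another on an aromatic carbon, but it has no readable size and shows no direction. Given a step that the two limits leave unreadable from compound 1 to compound 2, compound 3 is expected to show no clear gain in this assay, and it will probably be reported as a limit again.

For compound 3 the estimated value is 50000 nM, with an expected range from 15000 nM to 100000 nM.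

This estimate means an expected a number no higher from compound 2 to compound 3 (the limit leaves the size open).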

Compound 3, half-maximal inhibitory concentration: > 50000 nM
Compound 3: a limit, no number; the forecaster's own chance of this, stated with the estimate: 85%; the middle value sits exactly at the limit.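

In this assay compound 3 gives > 50000 nM, a limit and not a number. Within the data shown here, no step among compound 1, compound 2 and compound 3 can be read, so the exchanges of cyano, iodo and dimethylamino show neither a size nor a direction. The compounds shown leave open whether any group at that place would give an exact reading.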